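Naphthalenyl for methoxyphenyl on a weak chloro analogue

A few compounds are considered here, and "the series" means these few. Any claim that something is new, unique, unknown or untested is made for them only; others in the source may bear on it.

Compound 1 `COc1ccc(C2=NN(C3=NC(=O)/C(=C4\C(=O)Nc5ccc(Br)cc54)S3)C(c3ccc(OC)cc3)C2)cc1` and compound 2 `COc1ccc(C2CC(c3ccc4ccccc4c3)=NN2C2=NC(=O)/C(=C3\C(=O)Nc4ccc(Br)cc43)S2)cc1` share one core; compound 3 `COc1ccc(C2=NN(C3=NC(=O)/C(=C4\C(=O)Nc5ccccc54)S3)C(c3ccc(Cl)cc3)C2)cc1` and compound 4 `O=C1N=C(N2N=C(c3ccc4ccccc4c3)CC2c2ccc(Cl)cc2)S/C1=C1/C(=O)Nc2ccccc21` share another, and the difference between the two cores is not broken down here. In a functional assay on cells (Melanoma cell, Homo sapiens) for cytotoxicity, read by sulforhodamine B assay, with a stated time of 48 h (a higher number here means a weaker inhibitor of growth, a lower number a stronger inhibitor of growth), compound 1 gives 190 nM, compound 2 gives 69 nM and compound 3 gives 100000 nM, the highest number of the three measured.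

The measured step naphthalen-2-yl in place of 4-methoxyphenyl on a carbon with a double bond to nitrogen produced a 2.8-fold lower number from compound 1 to compound 2 (0.44 log units; beyond the scatter). The change planned for compound 4, (naphthalen-2-yl in place of 4-methoxyphenyl on a carbon with a double bond to nitrogen), is the same kind of change, not the same: around the place the ring atom bears a 4-chlorophenyl group rather than a 4-methoxyphenyl group.

On this one measured precedent, a step of similar direction and size is expected in this assay, giving a 2.5-fold lower number from compound 3 to compound 4 (0.40 log units; beyond the scatter) from compound 3. The expectation rests on a single pair and on compound 3 starting from a very weak position, so it is loosely held. For compound 4 the estimate in this assay is 40000 nM, with a range from 8000 nM to 100000 nM.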

Compound 4, concentration for 50% growth inhibition: 350 nM
Compound 4: middle estimate off by 110-fold (2.06 log units), on the high side, outside the stated range (below it).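

In this assay, naphthalen-2-yl in place of 4-methoxyphenyl gives a 290-fold lower number from compound 3 to compound 4 (2.46 log units; beyond the scatter), and the change carries over between the two cores in direction but not in size: the same change on two cores in this assay, a 2.8-fold lower number (0.44 log units; beyond the scatter) from compound 1 to compound 2 and a 290-fold lower number (2.46 log units; beyond the scatter) from compound 3 to compound 4, 100-fold (2.02 log units) apart, beyond the scatter of two such steps

The size of this step therefore cannot be treated as a fixed increment transferable from one core to the other in this series. The pairs do not show which of the differences between the cores sets the size, whether the 4-chlorophenyl group or another feature, and two pairs give no rule for any further core.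

The compounds shown leave open whether the gain is specific to naphthalen-2-yl or would also appear with another group on the same carbon with a double bond to nitrogen, such as a plain phenyl or a phenyl bearing an amine or a carboxylic acid. Also open, on these data alone, is how either core responds when the 4-chlorophenyl group gives way to a longer chain.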